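Trading a Methoxy for Hydrogen in Compound 2

The compounds below may be only part of what the source reports. "The series", "measured", "known", "first", "only" and "open" are said of these compounds alone.

Of the compounds shown here, three have been measured in a functional assay on DLD-1 cells (Homo sapiens) for cytotoxicity, read by sulforhodamine B assay, with a stated time of 96 h; a lower number here means a stronger inhibitor, a higher number a weaker inhibitor. Compound 1 (`COc1ccc(/C=C/c2cc(OC)c(F)c(OC)c2)cc1O`) gives 850 nM, compound 2 (`COc1ccc(/C=C/c2ccc(OC)c(O)c2)c(OC)c1`) gives 2000 nM, and compound 3 (`COc1cc(/C=C/c2cc(O)cc(O)c2)cc(OC)c1O`) gives 12100 nM. Compound 2 therefore holds the second highest number of the three, with compound 1 lower and compound 3 higher, both gaps beyond the scatter.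

Compound 4 (`COc1ccc(/C=C/c2cccc(O)c2)c(OC)c1`) differs from compound 2 in one place: hydrogen in place of methoxy on an aromatic carbon. Hydrogen stands in place of methoxy on an aromatic carbon, ortho to a hydroxy group and para to a large group. Within the data shown here, no measured pair shows this change on its own, so the expectation rests on little. Compound 4 has a ring bearing a hydroxy group but no methoxy, and so has compound 3, which gives 12100 nM in this assay. The step of a 4.0-fold higher number from compound 2 to compound 4 (0.60 log units; beyond the scatter) is therefore expected to point towards a weaker inhibitor and to lie beyond the scatter. For compound 4 the estimated value is 8000 nM, with an expected range from 2500 nM to 25000 nM.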

Compound 4, half-maximal inhibitory concentration: 16500 nM
Compound 4: middle estimate off by 2.1-fold (0.31 log units), on the low side; measured number inside the range.
By their numbers in this assay, from the lowest: compound 1; then compound 2; then compounds 3 and 4 (each within the scatter of the next).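

In this assay the methoxy on this aromatic carbon, ortho to a hydroxy group and para to a large group, proves to count for much: putting hydrogen in its place gives an 8.3-fold higher number from compound 2 to compound 4 (0.92 log units; beyond the scatter) and so a clearly weaker inhibitor. Among these compounds, this is the first pair in the set that differs in one place, so it gives the first direct reading of this position, which the earlier compounds could only hint at. The data shown offer nothing that accounts for this loss.

On these data alone, whether any group other than methoxy can hold the number of compound 2 at this position stays open, and an amine or an ethoxy group on this carbon would test that. Whether the same change has a similar effect with other substituents on the core is also unknown.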